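The source may hold more compounds than are shown below. What is called first, only, known or untested is meant among the compounds shown, and "the series" means these compounds.

Three compounds share one core and differ only in the group carried on an amine nitrogen. In a functional assay on HeLa cells (Homo sapiens) for cytotoxicity, read by MTT assay, with a stated time of 48 h (on this read-out lower numbers stand for stronger inhibition and higher numbers for weaker inhibition), compound 3 `Cc1ccc(S(=O)(=O)/N=C(/CCNC2=CC(=O)c3ccccc3C2=O)Nc2ccc(Cl)cc2Cl)cc1` gives 20500 nM, the highest of the three numbers. Compound 1 `Cc1ccc(S(=O)(=O)/N=C(/CCNC2=CC(=O)c3ccccc3C2=O)Nc2ccc(Cl)cc2)cc1` gives 13400 nM, and the step of a 1.5-fold higher number from compound 1 to compound 3 (0.18 log units; within the scatter) stays within the scatter. Compound 2 `Cc1ccc(S(=O)(=O)/N=C(/CCNC2=CC(=O)c3ccccc3C2=O)Nc2ccccc2[N+](=O)[O-])cc1` gives 3310 nM, and the step of a 6.2-fold higher number from compound 2 to compound 3 (0.79 log units; beyond the scatter) lies beyond it. Compound 4 `Cc1ccc(S(=O)(=O)/N=C(/CCNC2=CC(=O)c3ccccc3C2=O)Nc2cc(F)c(F)c(F)c2)cc1` carries 3,4,5-trifluorophenyl in place of 2,4-dichlorophenyl on an amine nitrogen. For the measured compounds named here, no measured step exchanges one halogen pattern for another, so the nearest guide is a 1.5-fold higher number from compound 1 to compound 3 (0.18 log units; within the scatter), where an added chloro changed little. Compound 4 is therefore expected to stay close to compound 3, with a 1.4-fold lower number from compound 3 to compound 4 (0.14 log units; within the scatter) showing nothing beyond the scatter. The estimate for compound 4 is 15000 nM, ranging from 6000 nM to 40000 nM.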

Compound 4, half-maximal inhibitory concentration: 8580 nM
Beside the measured number, compound 4's estimate is 1.7-fold (0.24 log units) above it; the measured number falls inside the stated range.
By their numbers in this assay, from the lowest: compound 2; then compounds 4, 1 and 3 (each within the scatter of the next, the first and the last beyond it).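

In this assay, exchanging 2,4-dichlorophenyl for 3,4,5-trifluorophenyl on this amine nitrogen gives a 2.4-fold lower number from compound 3 to compound 4 (0.38 log units; beyond the scatter), so changing the halogen pattern here can move the number beyond the scatter, which adding a single chloro did not do. The 2-nitrophenyl group still gives the lowest number of the four, as a 2.6-fold higher number from compound 2 to compound 4 (0.41 log units; beyond the scatter) shows, while a 1.6-fold lower number from compound 1 to compound 4 (0.19 log units; within the scatter) leaves 4-chlorophenyl and 3,4,5-trifluorophenyl unseparated. Nothing available explains these differences. On these data alone, how a methoxyphenyl group or a plain ethyl chain on this nitrogen would compare remains open.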